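A few compounds are considered here, and "the series" means these few. Any claim that something is new, unique, unknown or untested is made for them only; others in the source may bear on it.

Measured so far in an ADME assay on HepG2 cells (Homo sapiens) for cytotoxicity, read by luminescence, with a stated time of 72 h; a lower number here means that less compound is needed, a higher number that more compound is needed for the effect:
compound 1 `CCOC(=O)c1c(-c2ccccc2)[nH]c2cc(OC)ccc2c1=O`: > 21500 nM
compound 2 `C=Cc1cccc(-c2[nH]c3cc(OC)ccc3c(=O)c2C(=O)OCC)c1`: > 21500 nM
compound 3 `CCOC(=O)c1c(-c2cccc(OC)c2)[nH]c2cc(OC)ccc2c1=O`: > 21500 nM

Compound 1 stands at > 21500 nM, which is a limit and not a number. It has no company of real numbers, as the record so far is the limit of > 21500 nM in this assay, at which 3 of the 3 values shown sit.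

The next compound is compound 4 `CCCOc1cccc(-c2[nH]c3cc(OC)ccc3c(=O)c2C(=O)OCC)c1`. Its change from compound 1 is propoxy in place of hydrogen on an aromatic carbon, meta to a large group.

Two measured changes bear on it. One is a step that the two limits leave unreadable from compound 1 to compound 3, with methoxy in place of hydrogen. The other is a step that the two limits leave unreadable from compound 1 to compound 2, with vinyl in place of hydrogen. Neither gives a size, so the expectation in this assay has no measured size or direction to lean on, and no clear change is expected. The expected step is a step that the limit leaves unreadable from compound 1 to compound 4. Compound 4 is estimated at 30000 nM, with an expected range from 15000 nM to 60000 nM. Most likely this assay will again report only a limit.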

Compound 4, half-maximal effective concentration: > 21500 nM
Compound 4: only a limit was reported (the forecaster's own chance of this, stated with the estimate: 85%); the middle value lies beyond the limit too.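

Compound 4 gives only a limit in this assay, as do compound 1, compound 2 and compound 3, so none of the steps among them can be read: the limit of > 21500 nM in this assay, at which 4 of the 4 values shown sit.

The compounds shown leave open whether hydrogen, vinyl, methoxy or propoxy at that place makes any difference in this assay.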